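A Fluorine Added to a Cathepsin S Inhibitor

The source may report more compounds than this note shows. Statements on the series, on what has been measured and on what is new or still open speak of the compounds shown alone.

Of the compounds shown here, two have so far been measured in an assay on isolated protein for inhibition of cathepsin S (Homo sapiens); a higher number here means a weaker inhibitor, a lower number a stronger inhibitor. Compound 1 `O=C(NCc1cc(-c2ccc(=O)n(CCCN3CCCC3)n2)ccc1Cl)c1ccccc1` gives 14000 nM. For the measured compounds named here, compound 2 `O=C(NCc1cc(-c2ccc(=O)n(CCCN3CCC(N4CCCC4=O)CC3)n2)ccc1Cl)c1ccccc1` gives 2300 nM, the lower of the two numbers, and the one measured step, a 6.1-fold lower number from compound 1 to compound 2 (0.78 log units; beyond the scatter), places it apart from compound 1 by more than the usual scatter. Compound 3 `O=C(NCc1cc(-c2ccc(=O)n(CCCN3CCC(N4CCCC4=O)CC3)n2)ccc1Cl)c1ccc(F)cc1` is compound 2 with a single alteration: fluoro in place of hydrogen on an aromatic carbon. Going by the values given here, the only measured step changes a different part of the molecule, the saturated chain on the far side of the shared core, and leaves the benzamide ring untouched, so it offers no guide to swapping hydrogen for fluoro on that ring. Nothing in the data therefore argues for a move in either direction beyond the scatter. For compound 3 the expected step in this assay is no change at the digits printed from compound 2 to compound 3 (within the scatter). Compound 3 is accordingly estimated at 2300 nM in this assay, with a likely range from 900 nM to 6000 nM.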

Compound 3, half-maximal inhibitory concentration: 1500 nM
For compound 3 the middle estimate is 1.5-fold (0.19 log units) above the measured one; the measured number falls inside the stated range.
By their numbers in this assay, from the lowest: compounds 3 and 2 (each within the scatter of the next); then compound 1.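

In this assay, the change from phenyl to 4-fluorophenyl gives a 1.5-fold lower number from compound 2 to compound 3 (0.19 log units; within the scatter), so compound 2 and compound 3 cannot be told apart by this measurement. For the compounds shown here, this is the first measured change on this ring, as the earlier step altered only the saturated chain on the far side of the shared core, and it shows that this ring carbon, para to a large group, can carry a single fluorine atom without a shift beyond the scatter. No measurement at hand says what lies behind so small a step, or whether it hides a small real effect of the fluoro.

As far as these compounds go, whether this position stays as insensitive to something larger, such as a chlorine atom, a methoxy group or a trifluoromethyl group, remains open, and so does the effect of a fluoro on another carbon of the same ring. Also open, from the compounds shown here alone, is whether a fluoro here would give a similarly small step on compound 1, which carries the simpler pyrrolidin-1-yl group at the end of its chain.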